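The source may hold more compounds than are shown below. What is called first, only, known or untested is meant among the compounds shown, and "the series" means these compounds.

In a functional assay on HL-60 cells (Homo sapiens) for inhibition, read by CCK-8 assay, with a stated time of 48 h (a higher number here means a weaker inhibitor, a lower number a stronger inhibitor), compound 3, `COc1ccc(Oc2ccccc2-c2ccsc2S(=O)(=O)N2CCN(C(=S)Nc3ccc([N+](=O)[O-])cc3)CC2)cc1OC`, gives > 50000 nM, which is a limit of the assay rather than a number. Compound 2, `COc1ccc(Oc2ccc([N+](=O)[O-])cc2-c2ccsc2S(=O)(=O)N2CCN(C(=S)Nc3ccc([N+](=O)[O-])cc3)CC2)cc1OC`, also sits at a limit in this assay, > 50000 nM. Within the data shown here, the one compound with a measured number is compound 1, `O=[N+]([O-])c1ccc(NC(=S)N2CCN(S(=O)(=O)c3sccc3-c3ccccc3Oc3ccc(O)c(O)c3)CC2)cc1`, which gives 5300 nM in this assay. The step of an at least 9.4-fold higher number from compound 1 to compound 3 (0.97 log units; beyond the scatter) shows that compound 3 is the weaker of the two by at least that much; the step that the two limits leave unreadable from compound 2 to compound 3 cannot be sized, since both ends are limits, as the limit of > 50000 nM in this assay, at which 2 of the 3 values shown sit, records.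

Compound 4, `COc1ccc(Oc2ccccc2-c2ccsc2S(=O)(=O)N2CCN(C(=O)Nc3ccc(F)cc3)CC2)cc1OC`, differs from compound 3 in one place: a group of 10 heavy atoms (7 carbon, 1 nitrogen, 1 oxygen, 1 fluorine; one six-membered aromatic ring of carbon only) in place of a group of 12 heavy atoms (7 carbon, 2 nitrogen, 2 oxygen, 1 sulfur; one six-membered aromatic ring of carbon only), on an amine nitrogen in a ring. Among the measured compounds shown here, no measured step covers this change; the two steps in hand concern the group on the oxygen of the aromatic ring and a nitro on an aromatic carbon, not the amine nitrogen in the ring. For the measured compounds named here, what can be said is that compound 3 already stands at the limit, and the only readable step in this assay places it far from the measured compound 1.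

With nothing to point the other way, compound 4 is expected to remain at or near the limit, with the step of a number no higher from compound 3 to compound 4 (the limit leaves the size open) estimated as none beyond the scatter. Compound 4 is therefore estimated at 50000 nM, between 12000 nM and 200000 nM.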

Compound 4, half-maximal inhibitory concentration: > 20000 nM
Compound 4: a limit, no number (the forecaster's own chance of this, stated with the estimate: 70%); the middle value does not contradict the limit.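

In this assay compound 4 gives > 20000 nM, which is a limit and not a number. Among these compounds, compound 3 also stands at a limit, so no step between compound 3 and compound 4 can be read. The compounds shown leave open whether the (4-fluorophenyl)carbamoyl group in compound 4 gives weaker or stronger inhibition than the group it replaces in compound 3.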